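Swapping bromo for methoxy in a whole-mouse test

The compounds below may be only part of what the source reports. "The series", "measured", "known", "first", "only" and "open" are said of these compounds alone.

In a functional assay on the whole organism (strain Kunming) with Mus musculus as the target, with a stated time of 0.5 h (on this read-out lower numbers stand for an effect already at smaller amounts and higher numbers for an effect only at larger amounts of compound), compound 1 (`COc1cc(OC)c(OC)cc1/C=C/COC(=O)/C=C/c1cc(OC)c(OC)c(OC)c1OC`) gives > 421 umol/kg as its result, which is a limit and not a number. Compound 2 (`COc1cc(OC)c(OC)cc1/C=C/COC(=O)/C=C/c1ccc(Br)cc1`) gives > 692 umol/kg as its result, and this too is only a limit. For the measured compounds named here, compound 2 therefore has no measured dose, and the two results yield no step to learn from. Compound 3 (`COc1ccc(/C=C/C(=O)OC/C=C/c2cc(OC)c(OC)cc2OC)cc1`) has methoxy in place of bromo on an aromatic carbon. A modest shift towards smaller doses is expected, the estimated step running an at least 1.3-fold lower number from compound 2 to compound 3 (0.14 log units; that floor lies within the scatter) in this assay at most. For compound 3 the estimate is 500 umol/kg with an expected range from 150 umol/kg to 900 umol/kg and another limit remains quite possible.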

Compound 3, dose for half-maximal effect: > 780 umol/kg
Compound 3: a limit, no number; the forecaster's own chance of this, stated with the estimate: 60%; middle value at least 1.5-fold (0.19 log units) away from the limit.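

For the compounds shown here, compound 3 also gives only a limit in this assay, > 780 umol/kg, so no step from compound 2 to compound 3 can be read. What dose of any of these compounds gives a half-maximal effect stays open.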